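Swapping the pendant aryl group on the shared core

The compounds below may be only part of what the source reports. "The series", "measured", "known", "first", "only" and "open" are said of these compounds alone.

Measured so far:
compound 1 `COc1ccc(Oc2ccc3c(NCCCNCc4cc(F)ccc4OC)ccnc3c2)cc1` with 7000 nM
compound 2 `COc1ccc(F)cc1CNCCCNc1ccnc2cc(Cc3ccc(F)cc3Cl)ccc12` with 2460 nM
compound 3 `Fc1ccc(Cc2ccc3c(NCCCNCc4ccco4)ccnc3c2)c(Cl)c1` with 5730 nM

In an ADME assay on HepG2 cells (Homo sapiens) for cytotoxicity, read by luminescence, CellTiter-Glo and ATP content, with a stated time of 72 h (a lower number here means that less compound is needed, a higher number that more compound is needed for the effect), compound 2 gives the lowest number of the three. Its nearest neighbour is compound 3, a 2.3-fold higher number from compound 2 to compound 3 (0.37 log units; beyond the scatter), and the furthest is compound 1, whose value is reached by reversing the step of a 2.8-fold lower number from compound 1 to compound 2 (0.45 log units; beyond the scatter).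

Compound 4 `COc1ccc(-c2ccc3c(NCCCNCc4cc(F)ccc4OC)ccnc3c2)cc1` is not yet measured. It is built from compound 2 by one change: 4-methoxyphenyl in place of 2-chloro-4-fluorobenzyl on an aromatic carbon. Compound 1 carries a 4-methoxyphenoxy group at this very position, so the step of a 2.8-fold lower number from compound 1 to compound 2 (0.45 log units; beyond the scatter) bears most directly on the question: there, putting in the 2-chloro-4-fluorobenzyl group lowered the number modestly. Compound 4 removes that group again and brings in a 4-methoxyphenyl group, which shares the methoxy-bearing ring of compound 1 but lacks its linking oxygen. Because of a 2.8-fold lower number from compound 1 to compound 2 (0.45 log units; beyond the scatter), a modest move in the opposite direction is expected, back towards the value of compound 1, though the missing linking oxygen leaves room for a smaller shift. The step of a 2.3-fold higher number from compound 2 to compound 3 (0.37 log units; beyond the scatter), at the other end of the molecule, says little here.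

For compound 4 in this assay the estimate is 5000 nM, with a range from 2000 nM to 14000 nM, which is expected to mean a step of a 2.0-fold higher number from compound 2 to compound 4 (0.31 log units; beyond the scatter).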

Compound 4, half-maximal effective concentration: 5960 nM
Beside the measured number, compound 4's estimate is 1.2-fold (0.08 log units) below it; the range from low to high includes it.
By their numbers in this assay, from the lowest: compound 2; then compounds 3, 4 and 1 (each within the scatter of the next).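

In this assay, replacing the 2-chloro-4-fluorobenzyl group with 4-methoxyphenyl gives a 2.4-fold higher number from compound 2 to compound 4 (0.38 log units; beyond the scatter), so compound 2 now stands apart from a second group at this aromatic carbon, not only from the 4-methoxyphenoxy group of compound 1. The new comparison is with that 4-methoxyphenoxy group: taking out the linking oxygen gives a 1.2-fold lower number from compound 1 to compound 4 (0.07 log units; within the scatter), so at this position and in this assay, attaching the methoxy-bearing ring directly or through oxygen makes no difference that can be told from the scatter. The step from the 2-chloro-4-fluorobenzyl group is a bundled change, however, since the carbon link, the chlorine and the fluorine all leave while the methoxy group enters, and the step alone cannot assign its size to any one of these parts.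

No measurement shown here explains why the numbers fall as they do. As far as these compounds go, it also remains open whether a 4-methoxybenzyl group, which would keep the carbon link but carry no halogen, or a small amine on this aromatic carbon would give a number nearer to that of compound 2 or to those of compounds 1 and 4.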